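The compounds below may be only part of what the source reports. "The series", "measured", "known", "first", "only" and "open" are said of these compounds alone.

Working notes on the series. Compound 1 `NCCCCNc1cc(N2CCc3ccccc3C2)nc2ccccc12` and compound 2 `Cc1ccc2nc(N3CCCc4ccc(F)cc4C3)cc(NC(C)CN)c2c1` share a common core carrying a basic amino side chain on a ring nitrogen. In an ADME assay on HEp-2 cells (Homo sapiens) for cytotoxicity, read by CCK-8 assay, with a stated time of 5 days (on this read-out higher numbers stand for lower toxicity in this test and lower numbers for higher toxicity in this test), compound 1 gives 7400 nM. In this assay compound 2 gives 25000 nM, which is the higher of the two numbers recorded so far, and the gap between compound 2 and compound 1 lies beyond the usual scatter. For the measured compounds named here, these two compounds differ in more than one place, so no single step connects them; their two values are simply noted side by side.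

Compound 3 `Cc1ccc2nc(N3CCCc4ccc(F)cc4C3)cc(NCCNC3COC3)c2c1` is the next candidate for this assay. It differs from compound 2 in one place: 2-((oxetan-3-yl)amino)ethyl in place of 1-(aminomethyl)ethyl on a nitrogen on an aromatic ring. The side chain on the nitrogen on an aromatic ring therefore grows by three heavy atoms and gains a four-membered ring.

Going by the values given here, no measured step of this kind exists, so the size of the change in this assay cannot be read from the data. The step from compound 2 to compound 3 is expected to be no change at the digits printed from compound 2 to compound 3 (within the scatter), that is, nothing beyond the scatter. For compound 3 the estimate in this assay is 25000 nM, with a range from 9000 nM to 70000 nM.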

Compound 3, half-maximal cytotoxic concentration: > 100000 nM
Compound 3: a limit, no number; the forecaster's own chance of this, stated with the estimate: 25%; middle value at least 4.0-fold (0.60 log units) from the limit.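

In this assay compound 3 gives > 100000 nM, which is a limit of the assay and not a number: the limit of > 100000 nM in this assay, at which 1 of the 3 values shown sits.

Placing 2-((oxetan-3-yl)amino)ethyl in place of 1-(aminomethyl)ethyl on a nitrogen on an aromatic ring gives an at least 4.0-fold higher number from compound 2 to compound 3 (0.60 log units; beyond the scatter). For the compounds shown here, this is the first single-place step, and it shows that a change in this side chain alone, with the rest of the molecule held constant, can move the read-out beyond the scatter in the direction of lower toxicity in this test, although the full size of that move stays unknown.

The compounds shown do not separate the contribution of the four-membered ring from that of the chain carrying it, and a plain 2-aminoethyl or a 2-(cyclobutylamino)ethyl on the same nitrogen would bear on that question. On these data alone, whether the same change has a similar effect on the other substitution pattern of compound 1 also remains open, as a single step gives no information about how far it carries over.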